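The compounds below may be only part of what the source reports. "The series", "measured", "known", "first", "only" and "open" are said of these compounds alone.

Notes on the series. All three measured compounds share one core and differ only in the group on a double-bonded ring carbon of the six-membered non-aromatic ring. Among the measured compounds shown here, compound 1 `COc1ccccc1NC1=CC(=O)c2c(nc3n2[C@H]2OC[C@@H](O)[C@H]2OC3)C1=O` is the only compound with a numerical result: in a functional assay on MCF7 cells (Homo sapiens) for inhibition, read by sulforhodamine B assay (on this read-out higher numbers stand for weaker inhibition and lower numbers for stronger inhibition), compound 1 gives 6580 nM. Compound 2 `CCOc1ccccc1NC1=CC(=O)c2nc3n(c2C1=O)[C@H]1OC[C@@H](O)[C@H]1OC3` carries an ethoxy in place of the methoxy on the aryl amine; in this assay compound 2 reaches only the limit of > 4000 nM, so no number is known for it. Compound 3 `O=C1C=C(N2CCCCC2)C(=O)c2c1nc1n2[C@H]2OC[C@@H](O)[C@H]2OC1` bears a piperidine; in this assay compound 3 also sits at a limit, > 8000 nM, and yields no number. For the measured compounds named here, no step between measured compounds can be stated.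

Compound 4 `CCCN(CCC)C1=CC(=O)c2c(nc3n2[C@H]2OC[C@@H](O)[C@H]2OC3)C1=O` is not yet measured. It differs from compound 1 by dipropylamino in place of (2-methoxyphenyl)amino on a double-bonded ring carbon. The change removes the aromatic ring and the hydrogen-bond donor. Compound 3, the other dialkylamino member, gave only (the limit of > 8000 nM in this assay, at which 1 of the 3 values shown sits), which points toward weak inhibition for an open-chain dialkylamino as well. The expected step is therefore toward weaker inhibition, a 1.8-fold higher number from compound 1 to compound 4 (0.26 log units; within the scatter), likely beyond the scatter, with a real chance that only a limit is reported. Compound 4 is estimated at 12000 nM, with a range from 3500 nM to 40000 nM.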

Compound 4, half-maximal inhibitory concentration: > 16000 nM
Compound 4: only a limit was reported; the forecaster's own chance of this, stated with the estimate: 60%; middle value at least 1.3-fold (0.12 log units) away from the limit.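

In this assay, among the compounds shown here, the change at this double-bonded ring carbon gives an at least 2.4-fold higher number from compound 1 to compound 4 (0.38 log units; beyond the scatter) and is the first step that can be read at all, so the group at this position does bear on the read-out. Going from (2-methoxyphenyl)amino to dipropylamino removes the aromatic ring and the hydrogen-bond donor together, and this goes with weaker inhibition, although the true size of the step remains unknown because only its lower bound is available. Both dialkylamino compounds, compound 3 with its piperidine and compound 4 with its open chain, now end at limits of the assay and not at numbers, so the weak result is not confined to the ring-closed amine.

Steps among compound 2, compound 3 and compound 4 cannot be read, and the effect of ethoxy against methoxy on the aryl amine stays open with them. As far as these compounds go, it also remains open whether the aromatic ring or the amine hydrogen matters more: a propylamino group would keep the hydrogen without the ring, and an N-methyl-(2-methoxyphenyl)amino group would keep the ring without the hydrogen.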